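This account rests on a few compounds, and the source may have more. Where it says the series, first, only, none or still open, it means among the compounds named here.

Measured so far in this series:

compound 1 `Cn1c(-c2ccc(NC(=O)CCl)cc2)nc(-c2ccccc2)c1-c1ccccc1` — 14.2%
compound 2 `Cn1c(-c2ccc(NC(=O)CSc3nc4cc(Cl)ccc4o3)cc2)nc(-c2ccccc2)c1-c1ccccc1` — 27.7%

In a functional assay on MCF7 cells (Homo sapiens) for cytotoxicity, read by MTT assay, with a stated time of 24 h, tested at 6.4 ug/mL (on this read-out higher numbers stand for a stronger effect at the one concentration tested and lower numbers for a weaker effect), compound 2 gives 27.7%, the higher of the two numbers; its nearest neighbour is compound 1 with 14.2%. Going by the values given here, the single measured step, a number 13.5 percentage points higher from compound 1 to compound 2 (beyond the scatter), lies beyond the scatter, and it replaces chloro on a saturated chain carbon bound to a carbonyl carbon with the whole (5-chloro-1,3-benzoxazol-2-yl)sulfanyl group.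

Compound 3 `Cc1ccc2oc(SCC(=O)Nc3ccc(-c4nc(-c5ccccc5)c(-c5ccccc5)n4C)cc3)nc2c1` is still to be measured in this assay. It differs from compound 2 by methyl in place of chloro on an aromatic carbon. Among the compounds with values here, no measured step touches this place: the one step known concerns the arrival of the (5-chloro-1,3-benzoxazol-2-yl)sulfanyl group as a whole, not the exchange of one single-atom substituent for another on the aromatic carbon described. The change from compound 2 to compound 3 is therefore uncharted, and nothing in the two numbers suggests a shift in either direction beyond the scatter.

Compound 3 is accordingly expected to give 26%, estimated to fall between 14% and 38%. The expected step of a number 1.7 percentage points lower from compound 2 to compound 3 (within the scatter) is within the usual scatter.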

Compound 3, a percentage reported as activity, at one concentration (the size of the read-out at that concentration, not a potency): 24.6%
For compound 3 the middle estimate is 1.4 percentage points above the measured one; the range from low to high includes it.
By their numbers in this assay, from the lowest: compound 1; then compounds 3 and 2 (each within the scatter of the next).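

In this assay, the exchange on this aromatic carbon, meta to a fused ring and para to a fused ring, gives a number 3.1 percentage points lower from compound 2 to compound 3 (within the scatter), so at this position the read-out does not separate methyl from chloro. The step of a number 10.4 percentage points higher from compound 1 to compound 3 (beyond the scatter) stands beside a number 13.5 percentage points higher from compound 1 to compound 2 (beyond the scatter), and in these two compounds the rise over the chloro chain of compound 1 therefore does not depend on the chlorine of the (5-chloro-1,3-benzoxazol-2-yl)sulfanyl group, since the (5-methyl-1,3-benzoxazol-2-yl)sulfanyl group also lies beyond the scatter. No measured evidence bears on the reason for either step.

The compounds shown leave open whether a methoxy group, a carboxylic acid or a plain hydrogen on this aromatic carbon would read the same as methyl and chloro, so the tolerance seen so far covers only these two single-atom substituents. They also leave open how the rise over compound 1 divides between the sulfur link and the 1,3-benzoxazol-2-yl part, and, with a single concentration tested, whether the stronger or weaker effects seen at that concentration would hold at any other.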